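Purine acetamide series: side chain swap to isopropyl

This account rests on a few compounds, and the source may have more. Where it says the series, first, only, none or still open, it means among the compounds named here.

Measured so far:
compound 1 `N=C(N)NCCC[C@H](NC(=O)CN(c1nc(Cl)nc2[nH]cnc12)C1CC1)C(=O)O` — 27.6%
compound 2 `CC[C@H](C)[C@H](NC(=O)CN(c1ncnc2c1ncn2C1CCCCO1)C1CC1)C(=O)OCc1ccccc1` — 22.6%
compound 3 `NC(=O)C[C@H](NC(=O)CN(c1ncnc2c1ncn2C1CCCCO1)C1CC1)C(=O)OCc1ccccc1` — 35%

In a functional assay on the whole organism (Tail, strain ICR) with Mus musculus as the target, in the tail flick test, with a stated time of 90 min, at a dose of 25 umol/kg by the oral route (a lower number here means a weaker effect, a higher number a stronger effect of the compound at the dose given), compound 1 gives 27.6%, the second highest of the three numbers; its gaps to compound 2 and to compound 3 both lie within the scatter, so no order among the three can be stated.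

Compound 4 `CC(C)[C@H](NC(=O)CN(c1nc(Cl)nc2[nH]cnc12)C1CC1)C(=O)O` has not been measured. It differs from compound 1 by a group of 3 heavy atoms (3 carbon; no ring) in place of a group of 7 heavy atoms (4 carbon, 3 nitrogen; no ring), on a saturated chain carbon bound to an amide-type nitrogen and a carbonyl carbon.

For the measured compounds named here, the only step measured at this position is a number 12.4 percentage points higher from compound 2 to compound 3 (beyond the scatter), on a different core and with a benzyl ester in place of the free acid. There a hydrocarbon group gave way to a group carrying nitrogen and oxygen and the number rose modestly. Going by the values given here, the change from compound 1 to compound 4 runs the other way, a nitrogen-rich group leaving and a hydrocarbon group entering, so a modest fall in this assay is expected, a number 7.6 percentage points lower from compound 1 to compound 4 (within the scatter), though the single supporting step rests on a different core and the fall may not clear the scatter.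

Compound 4 is expected to give about 20%, within 8% to 32%.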

Compound 4, a percentage reported as activity, at one dose (the size of the read-out at that dose, not a potency): 30.3%
The estimate for compound 4 lay 10.3 percentage points below the measured number; the range from low to high includes it.
By their numbers in this assay, from the lowest: compounds 2, 1, 4 and 3 (each within the scatter of the next, the first and the last beyond it).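

In this assay, the step of a number 2.7 percentage points higher from compound 1 to compound 4 (within the scatter) lies within the scatter, so at this dose the two compounds cannot be told apart. On the core of compound 1 with its free acid, the group of 7 heavy atoms, with its 3 hydrogen-bond donors, can therefore give way to isopropyl, which has none, without a change that this read-out can resolve. No further data bear on this result.

As far as these compounds go, it remains open whether a primary amine at the end of a butyl chain, or a carboxylic acid on a shorter chain, would give a step beyond the scatter at this place on the same core. Also open, from the compounds shown here alone, is whether carbamoylmethyl on this core would repeat a number 12.4 percentage points higher from compound 2 to compound 3 (beyond the scatter), which was seen on a different core with a benzyl ester.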